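A Shorter Chain at the Assay Limit

This account rests on a few compounds, and the source may have more. Where it says the series, first, only, none or still open, it means among the compounds named here.

Compound 1 (`O=c1[nH]c(=O)n([C@H]2C[C@H](O)[C@@H](CO)O2)cc1CO`) with 9180 nM in an ADME assay on L1210/0 cells (Mus musculus) for cytotoxicity, with a stated time of 48 h; on this read-out lower numbers stand for stronger inhibition and higher numbers for weaker inhibition
Compound 2 (`N#Cc1cn([C@H]2C[C@H](O)[C@@H](CO)O2)c(=O)[nH]c1=O`) with > 200000 nM as a limit of the assay, not a number
Compound 3 (`O=c1[nH]c(=O)n([C@H]2C[C@H](O)[C@@H](CO)O2)cc1C#CCCCO`) with > 200000 nM as a limit of the assay, not a number

Compound 3 stands at the limit of > 200000 nM in this assay, at which 2 of the 3 values shown sit, and has no exact number. In compound 4 (`CCCc1cn([C@H]2C[C@H](O)[C@@H](CO)O2)c(=O)[nH]c1=O`) propyl takes the place of 5-hydroxypent-1-yn-1-yl on an aromatic carbon (propyl in place of 5-hydroxypent-1-yn-1-yl on an aromatic carbon). Two large measured steps bear on this change: an at least 21-fold higher number from compound 1 to compound 2 (1.33 log units; beyond the scatter) and an at least 21-fold higher number from compound 1 to compound 3 (1.33 log units; beyond the scatter) both lead away from the hydroxymethyl of compound 1. The third step, a step that the two limits leave unreadable from compound 2 to compound 3, cannot be sized. Compound 4 also lacks that hydroxymethyl, so it is expected to stay weak in this assay and close to the limit. The expected step is small, if anything towards a lower number: an at least 1.4-fold lower number from compound 3 to compound 4 (0.15 log units; that floor lies within the scatter) is the estimate. The estimated value for compound 4 is 140000 nM within a range from 40000 nM to 300000 nM. Compound 4 may again end up with no exact number, only a limit.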

Compound 4, half-maximal inhibitory concentration: > 200000 nM
Compound 4 ended at the assay's limit; the forecaster's own chance of this, stated with the estimate: 60%; at least 1.4-fold (0.15 log units) between middle value and limit.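

Replacing the hydroxymethyl with propyl gives an at least 21-fold higher number from compound 1 to compound 4 (1.33 log units; beyond the scatter), so a plain carbon chain with no hydrogen-bond donor or acceptor falls on the same weak side as the nitrile and the 5-hydroxypent-1-yn-1-yl group. Of the groups shown at this position, only the hydroxymethyl of compound 1 gives an exact number in this assay: the limit of > 200000 nM in this assay, at which 3 of the 4 values shown sit. The steps among compound 2, compound 3 and compound 4 cannot be read, as all three values are limits.

From the compounds shown here alone, it remains open whether a methyl or an aminomethyl group at this position would give an exact number, as hydroxymethyl does.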